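A few compounds are considered here, and "the series" means these few. Any claim that something is new, unique, unknown or untested is made for them only; others in the source may bear on it.

Measured so far in a functional assay on MCF7 cells (Homo sapiens) for antiproliferative activity, read by MTT assay, with a stated time of 72 h; on this read-out lower numbers stand for stronger inhibition and higher numbers for weaker inhibition:
compound 1 `COc1ccc(N2CCN(C(=S)SCc3ccc4nc(N)nc(N)c4c3)CC2)cc1` — 1580 nM
compound 2 `Nc1nc(N)c2cc(CSC(=S)N3CCN(c4ccccc4Cl)CC3)ccc2n1` — 3190 nM

Compound 2 stands at the highest of the two numbers, with compound 1 the nearest. Going by the values given here, the only measured step, a 2.0-fold higher number from compound 1 to compound 2 (0.31 log units; beyond the scatter), concerns the group on the amine nitrogen in the ring and is modest.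

Compound 3 `Nc1nc(N)c2cc(CSC(=S)N3CCN(c4ccccc4[N+](=O)[O-])CC3)ccc2n1` differs from compound 2 by nitro in place of chloro on an aromatic carbon. Among the compounds with values here, no measured step exchanges one substituent for another on that phenyl ring while keeping its position, so the single step in hand does not bear directly on this change; it only shows that altering the phenyl substituent shifted this assay by a modest amount. Hence no step beyond the scatter is expected from compound 2 to compound 3, a 1.1-fold higher number from compound 2 to compound 3 (0.04 log units; within the scatter), with a wide range to reflect the lack of a bearing step. Compound 3 is estimated at 3500 nM, between 1400 nM and 9000 nM.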

Compound 3, half-maximal inhibitory concentration: 4350 nM
Compound 3: the middle estimate sits 1.2-fold (0.09 log units) below what was measured; the measured number falls inside the stated range.
By their numbers in this assay, from the lowest: compound 1; then compounds 2 and 3 (each within the scatter of the next).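

In this assay, exchanging chloro for nitro on an aromatic carbon ortho to a large group gives a 1.4-fold higher number from compound 2 to compound 3 (0.13 log units; within the scatter), so this assay does not separate the two groups at this place, even though nitro adds heavy atoms and hydrogen-bond acceptors. Compound 3 also stands apart from the 4-methoxyphenyl compound, with a 2.8-fold higher number from compound 1 to compound 3 (0.44 log units; beyond the scatter), a modest step that matches compound 2 in lying beyond the scatter. No evidence on the origin of these steps is at hand.

Still open, on these data alone, is whether the gap to compound 1 follows the substituent itself or its place on the phenyl ring, as compound 1 and compound 3 differ in both. Also open, as far as these compounds go, is how an amine or a carboxylic acid on that same carbon would read in this assay.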